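The compounds below may be only part of what the source reports. "The series", "measured", "known", "first", "only" and "open" are said of these compounds alone.

Measured so far in an assay on HEK293 cells for inhibition of cytochrome P450 1A1 (Homo sapiens), read by fluorescence, with stated times of 30 min and 60 min; on this read-out lower numbers stand for stronger inhibition and higher numbers for weaker inhibition:
compound 1 `COc1ccc(/C=C/C(=O)c2ccncc2)cc1OC` gives 420 nM
compound 2 `CCOc1cc(/C=C/C(=O)c2ccncc2)cc(OC)c1OC` gives 63 nM

For the measured compounds named here, compound 1 stands highest of the two numbers; the one measured step, a 6.7-fold lower number from compound 1 to compound 2 (0.82 log units; beyond the scatter), runs downward and is beyond the scatter. Compound 3 `COc1ccc(/C=C/C(=O)c2ccncc2)c(OC)c1OC` differs from compound 1 by methoxy in place of hydrogen on an aromatic carbon. The step of a 6.7-fold lower number from compound 1 to compound 2 (0.82 log units; beyond the scatter) also adds an alkoxy group to the shared core, though at another place, so it bears only loosely on this change. A step downward is therefore expected in this assay, estimated as a 2.1-fold lower number from compound 1 to compound 3 (0.32 log units; beyond the scatter), with the size uncertain. For compound 3 the estimate is 200 nM, range 60 nM to 700 nM.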

Compound 3, half-maximal inhibitory concentration: 1330 nM
For compound 3 the middle estimate is 6.7-fold (0.82 log units) below the measured one; the measured number lies above the stated range.
By their numbers in this assay, from the lowest: compound 2; then compound 1; then compound 3.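

In this assay, methoxy in place of hydrogen on an aromatic carbon, ortho to a large group and ortho to a methoxy group, gives a 3.2-fold higher number from compound 1 to compound 3 (0.50 log units; beyond the scatter) and so shows that adding an alkoxy group to the shared core does not lower the number at every place. The downward direction of a 6.7-fold lower number from compound 1 to compound 2 (0.82 log units; beyond the scatter) does not carry over to this position. No measurement at hand accounts for the rise. Still open, from the compounds shown here alone, is whether the rise belongs to this place or to methoxy itself. A hydroxyl group, an amine or a longer alkoxy chain at the same place would help separate the two.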